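Trifluoromethyl for phenyl: from compound 1 to compound 4

A few compounds are considered here, and "the series" means these few. Any claim that something is new, unique, unknown or untested is made for them only; others in the source may bear on it.

Of the compounds shown here, three have numbers so far in a physicochemical assay for lipophilicity, read by HPLC, measured as chromatographic lipophilicity, at pH 7.4 (a lower number here means a more polar compound, a higher number a more lipophilic compound), and none of them forms a pair differing in one place. Compound 1 (`O=C(c1ccccc1)N1CCC(C(=O)N2N=CCC2c2ccccc2)CC1`) gives 4.4 and stands second highest of the three. Compound 2 (`O=C(C1CCCC1)N1N=CCC1c1ccccc1`) gives 5.4 and lies above compound 1 by more than the scatter. Compound 3 (`Cc1nnc(N2CCC(C(=O)N3N=CC[C@H]3c3ccccc3)CC2)o1`) gives 3.2 and lies below compound 1, also by more than the scatter.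

Compound 4 (`O=C(C1CCN(C(=O)C(F)(F)F)CC1)N1N=CCC1c1ccccc1`) is still unmeasured. It keeps the core of compound 1 and changes one group, with trifluoromethyl in place of phenyl on a carbonyl carbon. Cut one bond further out, the same difference reads benzoyl to (trifluoromethyl)carbonyl.

Among the compounds with values here, no measured step can be carried over to this change, so the expectation rests on judgement and starts from compound 1 at 4.4 in this assay as its anchor. A modest fall is expected, and the expected step is a number 0.40 log units lower from compound 1 to compound 4 (beyond the scatter) as a working figure. The estimate for compound 4 is 4 with an expected range from 3.5 to 4.6 on this scale.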

Compound 4, distribution coefficient: 4.9
Compound 4: the middle estimate sits 0.90 log units below what was measured, and the stated range ends below it.
By their numbers in this assay, from the lowest: compound 3; then compound 1; then compound 4; then compound 2.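

Within the data shown here, on the carbonyl carbon whose other neighbours are the amide-type nitrogen in a ring, trifluoromethyl in place of phenyl gives the first step that can be read at a single place. In this assay the number moves a number 0.50 log units higher from compound 1 to compound 4 (beyond the scatter) and so runs upward, although the entering group has fewer heavy atoms and no ring, and neither group counts any hydrogen-bond donor or acceptor. At this position, in this one pair, removing the aromatic ring therefore does not bring the number down, and nothing at hand bears on why the step takes this direction.

A single pair cannot separate what belongs to trifluoromethyl from what follows the removal of phenyl, and methyl, tert-butyl or cyclohexyl on the same carbonyl carbon would put that question to the test. From the compounds shown here alone, a dimethylamino group in that place would further show how far the step depends on a carbon-bound group there, while the size and direction of the step on any other core also remain open.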